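The compounds below may be only part of what the source reports. "The series", "measured", "known", "first", "only" and "open" are said of these compounds alone.

Going by the values given here, in a functional assay on DU-145 cells (Homo sapiens) for inhibition, read by trypan blue exclusion, with a stated time of 96 h (on this read-out higher numbers stand for weaker inhibition of growth and lower numbers for stronger inhibition of growth), two compounds have numbers so far. Compound 1 (`O=C(/C(=C\c1ccc(O)c([N+](=O)[O-])c1)S(=O)(=O)Cc1ccc(Br)cc1)c1c(F)c(F)c(F)c(F)c1F`) gives 50000 nM in this test, and compound 2 (`O=C(/C(=C\c1cc(Br)c(O)c(Br)c1)S(=O)(=O)Cc1ccc(Br)cc1)c1ccc(Br)cc1`) gives 25000 nM in the same test. These two numbers lie within the usual scatter of each other, so compound 2 stands level with compound 1 and the pair cannot be ranked. Compound 3 (`O=C(/C(=C\c1ccc(O)c([N+](=O)[O-])c1)S(=O)(=O)Cc1ccc(Br)cc1)c1ccc(Br)cc1`) is compound 2 with one group exchanged: 4-hydroxy-3-nitrophenyl in place of 3,5-dibromo-4-hydroxyphenyl on a double-bonded chain carbon bound to a double-bonded chain carbon. Among the compounds with values here, no measured pair shows this exchange alone, so there is no direct precedent for it. Within the data shown here, the only indirect evidence is that compound 1, which carries the entering group, gives 50000 nM while compound 2, which lacks it, gives 25000 nM and the two stay within the scatter. No shift beyond the scatter is therefore expected in this assay, and any drift would most likely be towards weaker inhibition of growth. The expected change is small, an estimated 1.2-fold higher number from compound 2 to compound 3 (0.08 log units; within the scatter) and no more than the scatter. The estimated value for compound 3 is 30000 nM with an expected range from 10000 nM to 70000 nM in this test.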

Compound 3, concentration for 50% growth inhibition: 10000 nM
For compound 3 the middle estimate is 3.0-fold (0.48 log units) above the measured one; the range from low to high includes it.
By their numbers in this assay, from the lowest: compound 3; then compounds 2 and 1 (each within the scatter of the next).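

In this assay the exchange to 4-hydroxy-3-nitrophenyl in place of 3,5-dibromo-4-hydroxyphenyl on a double-bonded chain carbon bound to a double-bonded chain carbon gives a 2.5-fold lower number from compound 2 to compound 3 (0.40 log units; beyond the scatter) and so shows that the number responds to the group at this position, which compounds 1 and 2 could not show, as they differ in more than one place and stand within the scatter of each other. Compound 3 also supplies a second single change, 4-bromophenyl in place of 2,3,4,5,6-pentafluorophenyl on a carbonyl carbon, which gives a 5.0-fold lower number from compound 1 to compound 3 (0.70 log units; beyond the scatter) with the 4-hydroxy-3-nitrophenyl group held fixed, so the number responds to the group on the carbonyl carbon as well. No measurement at hand says why either exchange moves the number.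

On these data alone, each change is seen only once, so it stays open whether the exchange on the chain carbon would give a step of like size with 2,3,4,5,6-pentafluorophenyl on the carbonyl carbon. As far as these compounds go, it is also open how the number would respond to a phenyl ring carrying an amine or a carboxylic acid in place of the nitro group at this position.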